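The source may report more compounds than this note shows. Statements on the series, on what has been measured and on what is new or still open speak of the compounds shown alone.

In an ADME assay on Vero cells (Chlorocebus sabaeus) for cytotoxicity, read by MTT assay, with a stated time of 96 h (a lower number here means that less compound is tolerated, a higher number that more compound is tolerated), compound 1 (`CC(=O)c1ccc2[nH]c(-c3ccc(Cl)cc3)nc2c1`) gives > 100000 nM as a limit of the assay. Compound 2 (`CC(=O)c1ccc2c(c1)nc(-c1ccc(Cl)cc1)n2C1CCCCC1`) gives > 100000 nM as a limit too, so it stands at a limit and has no number. The record so far is the limit of > 100000 nM in this assay, at which 2 of the 2 values shown sit, and nothing more. For the measured compounds named here, the only measured change is a step that the two limits leave unreadable from compound 1 to compound 2 and it gives no size to carry forward.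

Compound 3 (`CC(=O)c1ccc2c(c1)nc(-c1ccoc1)n2C1CCCCC1`) carries furan-3-yl in place of 4-chlorophenyl on an aromatic carbon. Going by the values given here, no measured step covers a change at this place. In this assay no step beyond the scatter is expected, and no direction can be read. This expectation rests on the limit of compound 2 at > 100000 nM alone. The expected change is a number no higher from compound 2 to compound 3 (the limit leaves the size open) as estimated here. For compound 3 the expected value is 100000 nM with an estimated range from 30000 nM to 300000 nM in this series.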

Compound 3, half-maximal cytotoxic concentration: 80000 nM
Beside the measured number, compound 3's estimate is 1.3-fold (0.10 log units) above it, and the stated range covers the measured number.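

In this assay, for the compounds shown here, compound 3 gives 80000 nM, the first value that is a number and not a limit. As far as these compounds go, at this carbon, furan-3-yl in place of 4-chlorophenyl gives an at least 1.2-fold lower number from compound 2 to compound 3 (0.09 log units; that floor lies within the scatter), and the full size of the step stays unknown, with only its floor readable. The earlier step cannot be read, and the series still rests largely on a limit: the limit of > 100000 nM in this assay, at which 2 of the 3 values shown sit.

From the compounds shown here alone, how far the number would move with an amine or a carboxylic acid on this carbon remains open. Also open, going by these compounds, is whether furan-3-yl gives a similar reading with hydrogen in place of cyclohexyl on the aromatic nitrogen.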